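The source may report more compounds than this note shows. Statements on the series, on what has been measured and on what is new or still open speak of the compounds shown alone.

Values measured in a functional assay on MDA-MB-231 cells (Homo sapiens) for antiproliferative activity, read by MTT assay, with a stated time of 72 h; on this read-out higher numbers stand for weaker inhibition and lower numbers for stronger inhibition

Compound 1 `O=C(CCc1cccc2c1B(O)OC2)Nc1ccccc1` gives 230 nM
Compound 2 `O=C(CCc1cccc2c1B(O)OC2)Nc1cccc(-c2cccc(F)c2)c1` gives 570 nM
Compound 3 `COc1ccc(-c2cccc(NC(=O)CCc3cccc4c3B(O)OC4)c2)cc1` gives 88 nM

Compound 3 has the lowest number of the three. It stands clear of the other two, with a 2.6-fold lower number from compound 1 to compound 3 (0.42 log units; beyond the scatter) and a 6.5-fold lower number from compound 2 to compound 3 (0.81 log units; beyond the scatter). The next compound to be read in this assay is compound 4 `COc1cc(OC)cc(-c2cccc(NC(=O)CCc3cccc4c3B(O)OC4)c2)c1`. It differs from compound 3 in one place, on an aromatic carbon of a six-membered aromatic ring of carbon only, meta to a large group, where 3,5-dimethoxyphenyl stands in place of 4-methoxyphenyl: 3,5-dimethoxyphenyl in place of 4-methoxyphenyl on an aromatic carbon.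

Among the compounds with values here, three measured steps bear on this change. Putting a substituted phenyl on the core of compound 1 went both ways, with a 2.5-fold higher number from compound 1 to compound 2 (0.39 log units; beyond the scatter) for 3-fluorophenyl against a 2.6-fold lower number from compound 1 to compound 3 (0.42 log units; beyond the scatter) for 4-methoxyphenyl. Within the data shown here, the closest precedent is the exchange of one substituted phenyl for another, a 6.5-fold lower number from compound 2 to compound 3 (0.81 log units; beyond the scatter), so a change of this kind can pass beyond the scatter. Among the measured compounds shown here, no measured compound carries 3,5-dimethoxyphenyl, and two substituted phenyls establish no rule. Compound 3 already holds the lowest number at 88 nM, so a rise is thought likelier than a further fall. A modest step is expected, estimated as a 2.3-fold higher number from compound 3 to compound 4 (0.36 log units; beyond the scatter). For compound 4 the expected value is 200 nM, with an estimated range from 60 nM to 650 nM.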

Compound 4, half-maximal inhibitory concentration: 40 nM
For compound 4 the middle estimate is 5.0-fold (0.70 log units) above the measured one; the whole stated range lies above it.
By their numbers in this assay, from the lowest: compound 4; then compound 3; then compound 1; then compound 2.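

In this assay, this position, on an aromatic carbon meta to a large group, had not reached its floor with 4-methoxyphenyl: a further fall, a 2.2-fold lower number from compound 3 to compound 4 (0.34 log units; beyond the scatter), came with 3,5-dimethoxyphenyl, which carries one more oxygen than the group it replaces. Against the unsubstituted phenyl the gain is now wider, a 5.8-fold lower number from compound 1 to compound 4 (0.76 log units; beyond the scatter), and against 3-fluorophenyl it is the one large step in the set, a 14-fold lower number from compound 2 to compound 4 (1.15 log units; beyond the scatter), so among these four compounds both phenyls bearing methoxy sit below compound 1, while the fluorinated one, in compound 2, sits above it. Nothing measured here accounts for these differences.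

The compounds shown do not separate the effect of having two methoxy groups from the effect of where they stand, since the two methoxy-bearing phenyls differ in both count and placement. From the compounds shown here alone, it also remains open whether a hydroxyl or an amine on this phenyl in place of methoxy would hold the number, and whether a longer chain in place of the one joining the amide carbonyl to the shared core would keep it.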